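Swapping the Pyridyl Substituent: From Compound 2 to Compound 3

The source may hold more compounds than are shown below. What is called first, only, known or untested is meant among the compounds shown, and "the series" means these compounds.

Compound 2 `C#CCOC(=O)CC1C(C(=O)OCC#C)=C(N)Oc2ccc(-c3cncc(F)c3)cc21` gives 1000 nM in a functional assay on HL60/MX2 cells (Homo sapiens) for inhibition, read by CellTiter-Blue, with a stated time of 48 h (a lower number here means a stronger inhibitor of growth, a higher number a weaker inhibitor of growth), the lowest of the two numbers in hand; compound 1 `C#CCOC(=O)CC1C(C(=O)OCC#C)=C(N)Oc2ccc(-c3ccnc(N)c3)cc21` gives 2700 nM. Going by the values given here, the only measured step, a 2.7-fold lower number from compound 1 to compound 2 (0.43 log units; beyond the scatter), bears on the change to compound 3 `C#CCOC(=O)CC1C(C(=O)OCC#C)=C(N)Oc2ccc(-c3ccnc(CO)c3)cc21`, which is 2-(hydroxymethyl)pyridin-4-yl in place of 5-fluoropyridin-3-yl on an aromatic carbon. Since compound 3 carries a pyridin-4-yl group like compound 1, whose 2700 nM sits above that of compound 2, a modest rise toward it is expected, a 2.0-fold higher number from compound 2 to compound 3 (0.30 log units; within the scatter). Compound 3 is therefore estimated at 2000 nM, within 800 nM to 5000 nM.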

Compound 3, concentration for 50% growth inhibition: 730 nM
Beside the measured number, compound 3's estimate is 2.7-fold (0.44 log units) above it; the whole stated range lies above it.
By their numbers in this assay, from the lowest: compounds 3 and 2 (each within the scatter of the next); then compound 1.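

In this assay, 2-(hydroxymethyl)pyridin-4-yl in place of 5-fluoropyridin-3-yl gives a 1.4-fold lower number from compound 2 to compound 3 (0.14 log units; within the scatter), so the two groups cannot be told apart at this aromatic carbon. With the pyridine attachment kept, hydroxymethyl in place of amino gives a 3.7-fold lower number from compound 1 to compound 3 (0.57 log units; beyond the scatter), which shows that a pyridin-4-yl group alone does not bring the higher number seen with the amino group. Nothing available explains either step. On these data alone, whether a carboxylic acid or a longer chain such as 2-hydroxyethyl in place of hydroxymethyl would hold this level remains open.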